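A Halogen Swap on the Aryl Carbonyl

The compounds below may be only part of what the source reports. "The series", "measured", "known", "first", "only" and "open" are said of these compounds alone.

Measured in a functional assay on A-375 cells (Homo sapiens) for cytotoxicity, read by MTT assay, with a stated time of 48 h; a lower number here means a stronger inhibitor, a higher number a weaker inhibitor:
Compound 1 `CC1(C)S[C@@H]2/C(=C\C(=O)c3cc(F)cc(F)c3)C(=O)N2[C@H]1C(=O)OC(c1ccccc1)c1ccccc1` gives 19100 nM.
Compound 2 `CC1(C)[C@H](C(=O)OC(c2ccccc2)c2ccccc2)N2C(=O)/C(=C/C(=O)c3ccc([N+](=O)[O-])cc3)[C@H]2[S+]1[O-]` gives 48200 nM.
Compound 3 `CC1(C)S[C@@H]2C/C(=C\C(=O)c3ccccc3)C(=O)N2[C@H]1C(=O)OC(c1ccccc1)c1ccccc1` reaches only the assay limit, > 100000 nM.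

Of the two numbers, compound 1 stands lowest; compound 2 gives a higher number, and that gap lies beyond the usual scatter. Compound 3 gives a limit rather than a number, as the line the limit of > 100000 nM in this assay, at which 1 of the 3 values shown sits, shows. Compound 4 `CC1(C)S[C@@H]2/C(=C\C(=O)c3ccc(Cl)cc3)C(=O)N2[C@H]1C(=O)OC(c1ccccc1)c1ccccc1` differs from compound 1 in one place: 4-chlorophenyl in place of 3,5-difluorophenyl on a carbonyl carbon. Among the measured compounds shown here, no pair of measured compounds differing in one place is available to guide the size of this change, so in this assay the expected step of a 1.0-fold higher number from compound 1 to compound 4 (0.02 log units; within the scatter) is small, not beyond the scatter. Compound 4 is therefore estimated at about 20000 nM, with a likely range from 7000 nM to 60000 nM.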

Compound 4, half-maximal inhibitory concentration: 48600 nM
Compound 4: middle estimate off by 2.4-fold (0.39 log units), on the low side, and the stated range covers the measured number.
By their numbers in this assay, from the lowest: compound 1; then compounds 2 and 4 (each within the scatter of the next). At a limit, above all of these: compound 3.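

In this assay, among the compounds shown here, 4-chlorophenyl in place of 3,5-difluorophenyl on a carbonyl carbon gives a 2.5-fold higher number from compound 1 to compound 4 (0.41 log units; beyond the scatter) and is the first change in a single place that can be read. It shows that the aryl group at this position can shift the number, though only modestly. Nothing measured here explains the size or direction of this step.

As far as these compounds go, how a ring carrying an amine or a methoxy group would compare at this position remains open. So does whether a pyridine ring could replace the aryl ring.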